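This account rests on a few compounds, and the source may have more. Where it says the series, first, only, none or still open, it means among the compounds named here.

Series notes on the shared core. In a functional assay on SK-MEL-2 cells (Homo sapiens) for cytotoxicity, read by sulforhodamine B assay, with a stated time of 2 days, tested at 100 uM (on this read-out higher numbers stand for more inhibition at the one concentration tested (going by the name of the read-out) and lower numbers for less inhibition), compound 1 `CCCc1n[nH]c2c(=O)n(NC(=O)c3ccncc3)c(-c3cccc(OC)c3)nc12` gives 11.4%. Compound 2 `O=C(Nn1c(-c2cccc([N+](=O)[O-])c2)nc2c(-c3ccc(Cl)cc3)n[nH]c2c1=O)c1cccnc1` gives 16.3% in this assay, and compound 3 `O=C(Nn1c(-c2cccc([N+](=O)[O-])c2)nc2c(-c3ccc(F)cc3)n[nH]c2c1=O)c1cccnc1` gives 24.5%. Compound 3 thus carries the top number of the three; its separation from compound 2 is within the scatter, while its separation from compound 1 lies beyond it. The next compound is compound 4 `O=C(Nn1c(-c2cccc([N+](=O)[O-])c2)nc2c(-c3ccco3)n[nH]c2c1=O)c1cccnc1`, with furan-2-yl in place of 4-fluorophenyl on an aromatic carbon. Going by the values given here, the only measured step at this position is a number 8.2 percentage points higher from compound 2 to compound 3 (within the scatter), within the scatter, so the numbers give no sign that exchanging the group on this carbon moves the read-out far. A step of a number 5.5 percentage points lower from compound 3 to compound 4 (within the scatter) is therefore expected, not beyond the scatter. Compound 4 is estimated at 19%, between 6% and 34%.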

Compound 4, a percentage reported as inhibition, at one concentration (the size of the read-out at that concentration, not a potency): 19.2%
Estimate against measurement, compound 4: 0.2 percentage points below; the measured number falls inside the stated range.
By their numbers in this assay, from the lowest: compounds 1, 2, 4 and 3 (each within the scatter of the next, the first and the last beyond it).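

At this position, the step to furan-2-yl gives a number 5.3 percentage points lower from compound 3 to compound 4 (within the scatter) and, against 4-chlorophenyl, a number 2.9 percentage points higher from compound 2 to compound 4 (within the scatter). The earlier step exchanged only the halogen on a six-membered aromatic ring, whereas this change swaps the ring itself for a five-membered aromatic ring with a hydrogen-bond acceptor, and the read-out still stays within the scatter. No evidence on the reason for this is at hand.

Going by these compounds, whether an amine or a carboxylic acid on this carbon would move the read-out beyond the scatter stays open.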